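Moving from Methoxy to Hydroxy on the Aryl Ring

The source may hold more compounds than are shown below. What is called first, only, known or untested is meant among the compounds shown, and "the series" means these compounds.

Compound 1 `Cc1ncc([N+](=O)[O-])n1CCSc1nnc(-c2ccccc2)o1`: 20500 nM
Compound 2 `Cc1ccccc1-c1nnc(SCCn2c([N+](=O)[O-])cnc2C)o1`: 15800 nM
Compound 3 `COc1ccc(-c2nnc(SCCn3c([N+](=O)[O-])cnc3C)o2)cc1`: 10600 nM

Of the compounds shown here, three of one series have been measured in a functional assay on MCF7 cells (Homo sapiens) for cytotoxicity, read by MTT assay, with a stated time of 48 h; a lower number here means a stronger inhibitor, a higher number a weaker inhibitor. Compound 1 gives 20500 nM, compound 2 gives 15800 nM, and compound 3 gives 10600 nM. Compound 3 holds the lowest of the three numbers, yet the steps of a 1.9-fold lower number from compound 1 to compound 3 (0.29 log units; within the scatter) and a 1.5-fold lower number from compound 2 to compound 3 (0.17 log units; within the scatter) both lie within the scatter, as does a 1.3-fold lower number from compound 1 to compound 2 (0.11 log units; within the scatter), so none of the three can be set apart from the others.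

Compound 4 `Cc1ncc([N+](=O)[O-])n1CCSc1nnc(-c2ccccc2O)o1` has not yet been measured. It differs from compound 3 in one place: 2-hydroxyphenyl in place of 4-methoxyphenyl on an aromatic carbon. For the measured compounds named here, the steps that bear on this change are the two that alter the same aryl ring: a 1.9-fold lower number from compound 1 to compound 3 (0.29 log units; within the scatter), where methoxy enters in place of hydrogen, and a 1.5-fold lower number from compound 2 to compound 3 (0.17 log units; within the scatter), where 4-methoxyphenyl replaces 2-methylphenyl. Going by the values given here, both fall within the scatter, and no measured step shows a hydroxyl on this ring at all. On this basis no movement beyond the scatter is expected. Compound 4 is estimated to give 13000 nM, with a range from 5500 nM to 32000 nM. The step of a 1.2-fold higher number from compound 3 to compound 4 (0.09 log units; within the scatter) is accordingly expected to remain within the usual scatter.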

Compound 4, half-maximal inhibitory concentration: 28300 nM
Estimate against measurement, compound 4: 2.2-fold (0.34 log units) below; low and high end bracket the measured number.
By their numbers in this assay, from the lowest: compounds 3, 2, 1 and 4 (each within the scatter of the next, the first and the last beyond it).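

In this assay, this aryl position now gives its first step beyond the scatter: a 2.7-fold higher number from compound 3 to compound 4 (0.43 log units; beyond the scatter), with 2-hydroxyphenyl in place of 4-methoxyphenyl. The result is confined to that one comparison, since a 1.8-fold higher number from compound 2 to compound 4 (0.25 log units; within the scatter) and a 1.4-fold higher number from compound 1 to compound 4 (0.14 log units; within the scatter) both stay within the scatter, so the hydroxy group does not set compound 4 apart from the compounds carrying methyl or hydrogen on the ring. Nothing measured here on these compounds beyond their cytotoxicity bears on why the step from methoxy to hydroxy exceeds the scatter.

The change alters both the group and its place on the ring, so the compounds shown cannot tell whether the step belongs to the exchange of oxygen substituent, to where it sits, or to both together. From the compounds shown here alone, it also remains open whether an amine or a carboxylic acid on this ring would give a number that stands beyond the scatter of all four compounds, and whether any such step would hold on other cells.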